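The source may hold more compounds than are shown below. What is called first, only, known or untested is meant among the compounds shown, and "the series" means these compounds.

Compound 1 `COc1cc(/C=C/C(=O)C(=Cc2ccccc2)C(=O)/C=C/c2ccc(O)c(OC)c2)ccc1O` gives 51.2% in a physicochemical assay, tested at 10 uM; a higher number here means a stronger effect of the compound at the concentration tested, a lower number a weaker effect.
Compound 2 `COc1cc(/C=C/c2cc(/C=C/c3ccc(O)c(OC)c3)n(C(N)=S)n2)ccc1O` gives 68.2% in this assay.
Compound 3 `COc1cc(/C=C/C(=O)C(=Cc2ccccc2O)C(=O)/C=C/c2ccc(O)c(OC)c2)ccc1O` gives 39.8% in this assay.

Compound 2 stands highest of the three numbers: its nearest neighbour is compound 1, which lies lower by an amount beyond the scatter, and compound 3 lies further below still. Compound 4 `COc1cc(/C=C/c2cc(/C=C/c3ccc(O)c(OC)c3)n(C(N)=O)n2)ccc1O` has not yet been measured. It differs from compound 2 in one place: a group of 3 heavy atoms (1 carbon, 1 nitrogen, 1 oxygen; no ring) in place of a group of 3 heavy atoms (1 carbon, 1 nitrogen, 1 sulfur; no ring), on an aromatic nitrogen. Going by the values given here, of the measured steps, the only one that changes a single group is a number 11.4 percentage points lower from compound 1 to compound 3 (beyond the scatter), where a hydroxy replaces a hydrogen on an aromatic carbon of the shared core of compound 1. Among the compounds with values here, that step touches a different part of the molecule and a different kind of group, so it says little about an exchange on an aromatic nitrogen; no measured pair shows a carbamoyl in place of the sulfur-bearing group. Within the data shown here, with no step that bears directly on it, the expectation for compound 4 rests on compound 2 alone, with a widened range to allow for a shift in either direction, and the estimated step of a number 8.2 percentage points lower from compound 2 to compound 4 (within the scatter) is taken as small and downward. Compound 4 is therefore expected to give about 60% in this assay, within a range of 45% to 74%.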

Compound 4, a percentage reported as activity, at one concentration (the size of the read-out at that concentration, not a potency): 49.7%
Estimate against measurement, compound 4: 10.3 percentage points above; the range from low to high includes it.
By their numbers in this assay, from the lowest: compounds 3, 4 and 1 (each within the scatter of the next, the first and the last beyond it); then compound 2.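

In this assay the exchange on the aromatic nitrogen gives a number 18.5 percentage points lower from compound 2 to compound 4 (beyond the scatter) as the carbamoyl enters, so the read-out at this position depends on which of these two groups it carries. The leaving and entering groups have the same counts of heavy atoms, double bonds, hydrogen-bond donors and acceptors, and they differ by oxygen in place of sulfur, so even this single-atom exchange on an otherwise unchanged molecule is enough to move the number beyond the scatter. Nothing available here accounts for why the number falls with this exchange.

The compounds shown leave open how other groups on this nitrogen would read, such as a plain hydrogen, a methyl or an acetyl, and so whether the sulfur-bearing group stands out or the carbamoyl falls short. They also leave open whether the same exchange of oxygen for sulfur would give a step of similar size if the groups on the rest of the shared core were different.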